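Shortening the hydroxycarbamoyl chain of compound 1

This account rests on a few compounds, and the source may have more. Where it says the series, first, only, none or still open, it means among the compounds named here.

In a functional assay on U-251 cells (Homo sapiens) for inhibition, read by MTT assay, with a stated time of 48 h (on this read-out lower numbers stand for stronger inhibition and higher numbers for weaker inhibition), compound 1 `C#CCN(C)CCCOc1cc(NC(=O)CCCCCCCC(=O)NO)ccc1Cl` gives 11500 nM and compound 2 `C#CCN(C)CCCOc1cc(NCc2ccc(C(=O)NO)cc2)ccc1Cl` gives 10100 nM, and these two values lie within the usual scatter of each other. Compound 3 `C#CCN(C)CCCOc1cc(NC(=O)CCCCCCC(=O)NO)ccc1Cl` keeps the core of compound 1 but carries hydroxycarbamoyl in place of (hydroxycarbamoyl)methyl on a saturated chain carbon, six bonds along the chain from a carbonyl carbon. Going by the values given here, no measured pair shows this kind of change. In this assay the expected outcome is therefore no step beyond the scatter (a 1.2-fold lower number from compound 1 to compound 3 (0.08 log units; within the scatter)). For compound 3 the estimated value is 9500 nM, with an expected range from 4000 nM to 22000 nM.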

Compound 3, half-maximal inhibitory concentration: 120 nM
Compound 3: middle estimate off by 79-fold (1.90 log units), on the high side; the measured number lies below the stated range.
By their numbers in this assay, from the lowest: compound 3; then compounds 2 and 1 (each within the scatter of the next).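

In this assay, the length of this chain matters sharply: hydroxycarbamoyl in place of (hydroxycarbamoyl)methyl, on an otherwise unchanged core, gives a large drop in the number (a 96-fold lower number from compound 1 to compound 3 (1.98 log units; beyond the scatter)). The earlier compounds shown here held no such one-place step, so this sensitivity to a small shortening could not be seen from them. No available evidence accounts for the size of this step.

From the compounds shown here alone, whether a still shorter chain would keep the low number remains open. So does whether a carboxylic acid in place of hydroxycarbamoyl would do the same.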